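A few compounds are considered here, and "the series" means these few. Any claim that something is new, unique, unknown or untested is made for them only; others in the source may bear on it.

Compound 3, `CNc1nc(NC2(C#N)CCCCC2)nc(N(C)C)n1`, carries a dimethylamino group on the shared core. In an in vitro assay on Sf21 cells for inhibition of high affinity 3',5'-cyclic-AMP phosphodiesterase 7A (Homo sapiens) (a lower number here means a stronger inhibitor, a higher number a weaker inhibitor), compound 3 gives only a limit, > 5000 nM, and no number. Two of the three values shown sit at this limit, which is the limit of > 5000 nM in this assay, at which 2 of the 3 values shown sit. Compound 1, `CNc1nc(NC2(C#N)CCCCC2)nc(-n2cncn2)n1`, with a 1H-1,2,4-triazol-1-yl group in the same place, likewise gives only a limit in this assay, > 5000 nM. Compound 2, `CNc1nc(NC2(C#N)CCCCC2)nc(-n2ccnc2)n1`, bearing 1H-imidazol-1-yl, is the only one of the three with a number, and in this assay compound 2 gives 1050 nM.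

Compound 4, `CNc1nc(NC2(C#N)CCCCC2)nc(SC)n1`, differs from compound 3 at one point: methylsulfanyl in place of dimethylamino on an aromatic carbon. The measured steps concern other exchanges at this carbon. The step of an at least 4.7-fold lower number from compound 1 to compound 2 (0.67 log units; beyond the scatter) and the step of an at least 4.7-fold higher number from compound 2 to compound 3 (0.67 log units; beyond the scatter) both run between an azolyl ring and another group, while the step that the two limits leave unreadable from compound 1 to compound 3 cannot be read because both ends are limits. Within the data shown here, no measured step exchanges dimethylamino for methylsulfanyl, so a direct size for this change is not available. Since compound 3 sits at the limit > 5000 nM and the entering group is again a small chain without a ring, compound 4 is expected to remain weak, with the step that the limit leaves unreadable from compound 3 to compound 4 estimated to stay within the scatter. The estimate for compound 4 in this assay is 6000 nM, in the range 2500 nM to 20000 nM.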

Compound 4, half-maximal inhibitory concentration: 46 nM
Beside the measured number, compound 4's estimate is 130-fold (2.12 log units) above it, outside the stated range (below it).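

In this assay, among these compounds, the earlier compounds at this position gave a number only with a ring attached, while dimethylamino, the one group without a ring, left only a limit, so a ring might have seemed necessary for a readable value. Methylsulfanyl, also without a ring, removes that reading: the exchange for dimethylamino gives an at least 100-fold lower number from compound 3 to compound 4 (2.03 log units; beyond the scatter), and the exchange for the triazolyl ring gives an at least 100-fold lower number from compound 1 to compound 4 (2.03 log units; beyond the scatter). It also surpasses the only ring that gave a number, with a 23-fold lower number from compound 2 to compound 4 (1.36 log units; beyond the scatter), which makes compound 4 the strongest inhibitor of the four and shows that this single carbon can control a large part of the inhibition on the shared core.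

On these data alone, how far compound 1 and compound 3 truly lie from compound 4 stays open, as each of them gives only a limit: the limit of > 5000 nM in this assay, at which 2 of the 4 values shown sit. The three earlier groups are all joined to the core through nitrogen and methylsulfanyl through sulfur, so it remains open whether the sulfur link itself matters or whether methoxy, ethylsulfanyl or a longer sulfur-linked chain at this carbon would serve as well.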